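From 3-chlorophenyl to 4-bromophenyl on a shared core

The compounds below may be only part of what the source reports. "The series", "measured", "known", "first", "only" and "open" are said of these compounds alone.

Compound 1 (`CC(C)(C)c1ccc(OCCCON2C(N)=NC(N)=NC23CCSCC3)cc1`): 70 nM
Compound 2 (`NC1=NC2(CCSCC2)N(OCCCOc2cccc(Cl)c2)C(N)=N1`): 90 nM

In a functional assay on HepG2 cells (Homo sapiens) for antiproliferative activity, read by MTT assay, with a stated time of 72 h (a higher number here means a weaker inhibitor, a lower number a stronger inhibitor), compound 2 (90 nM) stands level with compound 1 within the usual scatter of repeated measurements. Compound 3 (`NC1=NC2(CCSCC2)N(OCCCOc2ccc(Br)cc2)C(N)=N1`) carries 4-bromophenyl in place of 3-chlorophenyl on an oxygen on a saturated carbon. Among the compounds with values here, no measured pair shows this exchange on its own, so no step beyond the scatter is expected in this assay, in either direction. The estimated change is small (a 1.1-fold lower number from compound 2 to compound 3 (0.05 log units; within the scatter)). For compound 3 the expected value is 80 nM (range 30 nM to 220 nM).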

Compound 3, half-maximal inhibitory concentration: 1400 nM
Beside the measured number, compound 3's estimate is 18-fold (1.24 log units) below it, outside the stated range (above it).
By their numbers in this assay, from the lowest: compounds 1 and 2 (each within the scatter of the next); then compound 3.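

The aryl group on this oxygen-linked chain is less forgiving than compounds 1 and 2 suggested: in this assay, exchanging 3-chlorophenyl for 4-bromophenyl, with the same count of heavy atoms, gives a 16-fold higher number from compound 2 to compound 3 (1.19 log units; beyond the scatter). Changing tert-butyl to bromo on the aromatic carbon gives a 20-fold higher number from compound 1 to compound 3 (1.30 log units; beyond the scatter), so the substituent on this ring can strongly alter the result. From the compounds shown here alone, whether the loss follows the halogen or where it sits stays open, and a 3-bromophenyl or 4-chlorophenyl group would separate the two. No measurement here explains the loss.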